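Chloro for allyloxy: cytotoxicity step from compound 1

A few compounds are considered here, and "the series" means these few. Any claim that something is new, unique, unknown or untested is made for them only; others in the source may bear on it.

Compound 1 `C=CCOc1cc(C2=C(c3cc(OC)c(OC)c(OC)c3)C(=O)C(O)C2)ccc1OC` was tested in an ADME assay on HT-29 cells (Homo sapiens) for cytotoxicity, read by MTT assay, with a stated time of 72 h; on this read-out higher numbers stand for weaker inhibition and lower numbers for stronger inhibition. In this assay compound 1 returns only a limit of the assay, > 100 ug/mL, and not a number. Compound 2 `CCOC(=O)COc1ccc(C2=C(c3cc(OC)c(OC)c(OC)c3)C(=O)CC2O)cc1` is the other measured member of the series. In this assay compound 2 likewise sits at a limit, > 100 ug/mL. Compound 1 thus stands exactly where the whole measured set stands: the limit of > 100 ug/mL in this assay, at which 2 of the 2 values shown sit. Going by the values given here, no ranking between compound 1 and compound 2 can be drawn from two limits, and no step between them is given.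

Compound 3 `COc1ccc(C2=C(c3cc(OC)c(OC)c(OC)c3)C(=O)C(O)C2)cc1Cl` differs from compound 1 by chloro in place of allyloxy on an aromatic carbon. Among the compounds with values here, no measured step exists for this pair, so nothing shows how such a change moves the read-out. With both known values resting at the same limit, no shift beyond the usual scatter is expected; the change from compound 1 to compound 3 is estimated as a number no higher from compound 1 to compound 3 (the limit leaves the size open). Compound 3 is therefore expected to come out near 100 ug/mL, within 50 ug/mL to 200 ug/mL, and most probably to be reported again as a limit rather than as a number.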

Compound 3, half-maximal inhibitory concentration: < 1 ug/mL
Compound 3: only a limit was reported; the forecaster's own chance of this, stated with the estimate: 75%; middle value at least 100-fold (2.00 log units) away from the limit.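

In this assay, chloro in place of allyloxy on the aromatic carbon ortho to a methoxy group and meta to a large group gives an at least 100-fold lower number from compound 1 to compound 3 (2.00 log units; beyond the scatter). Going by these compounds alone, this is the first sign that the read-out responds strongly to the group at this one carbon, with the rest of the core of compound 1 left unchanged, so the earlier limits did not mean that the whole series sits at the weak end of the assay. Compound 3 gives < 1 ug/mL, a limit of the assay and not a number, and it now stands alone at the low end of the set: the limit of < 1 ug/mL in this assay, at which 1 of the 3 values shown sits.

The compounds shown leave open whether the step comes from the arrival of chloro or from the departure of allyloxy, a question that fluoro, bromo, hydroxy or an amine at the same carbon would begin to separate. Also open, on these data alone, are how far the true value of compound 3 lies past its limit and whether chloro at this carbon would have the same effect on a core carrying the ethyl ester side chain of compound 2.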